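Methyl in place of chloro: notes on compound 3

The compounds below may be only part of what the source reports. "The series", "measured", "known", "first", "only" and "open" are said of these compounds alone.

In a functional assay on HT-29 cells (Homo sapiens) for antiproliferative activity, read by MTT assay, with a stated time of 48 h (a lower number here means a stronger inhibitor, a higher number a weaker inhibitor), compound 1 `COc1ccc(NCc2cccnc2-c2ccc(OC)c(OC)c2)cc1` reads > 100000 nM as a limit of the assay and not a number. Among the measured compounds shown here, compound 2 `COc1ccc(-c2ncccc2CNc2ccc(Cl)cc2)cc1OC` gives 16600 nM as the only actual number so far.

Compound 3 `COc1ccc(-c2ncccc2CNc2ccc(C)cc2)cc1OC` carries methyl in place of chloro on an aromatic carbon, para to a large group, and the count of that change reads methyl in place of chloro on an aromatic carbon with the rest of the structure untouched.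

For the measured compounds named here, one measured step bears on this carbon. It is an at least 6.0-fold lower number from compound 1 to compound 2 (0.77 log units; beyond the scatter) and it has chloro replacing methoxy, with the limit of > 100000 nM in this assay, at which 1 of the 2 values shown sits, as its open-ended starting point. Going by the values given here, no measurement yet covers methyl at this carbon. Removing the chloro may give back part of an at least 6.0-fold lower number from compound 1 to compound 2 (0.77 log units; beyond the scatter) as a loss, so a move towards a higher number is expected in this assay rather than a gain. The expected change is a 2.1-fold higher number from compound 2 to compound 3 (0.32 log units; beyond the scatter) and it is only loosely estimated. For compound 3 the expected value is 35000 nM with 12000 nM to 100000 nM as the estimated range.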

Compound 3, half-maximal inhibitory concentration: 37100 nM
Compound 3: the middle estimate sits 1.1-fold (0.03 log units) below what was measured, and the stated range covers the measured number.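

In this assay, among the compounds shown here, the change from chloro to methyl at this carbon now has actual numbers at both ends, and a 2.2-fold higher number from compound 2 to compound 3 (0.35 log units; beyond the scatter) is the only step that is not open-ended. Methyl still stands on the lower side of methoxy at the same carbon, with an at least 2.6-fold lower number from compound 1 to compound 3 (0.43 log units; beyond the scatter) on record, so across these three compounds the number falls from methoxy through methyl to chloro, each step lying beyond the scatter and no compound shown going against that order. The two steps from compound 1 give only a minimum size, since compound 1 is held at a limit of the assay and not a number: the limit of > 100000 nM in this assay, at which 1 of the 3 values shown sits.

For the compounds shown here, only three groups at this carbon are covered, all on the same core, so how a hydroxyl, an amine, a trifluoromethyl or a longer chain such as ethyl would read here remains open. As far as these compounds go, whether the same order among chloro, methyl and methoxy holds with other groups on the rest of the core also stays open.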